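The source may hold more compounds than are shown below. What is called first, only, known or untested is meant among the compounds shown, and "the series" means these compounds.

Measured compounds and their values:

compound 1 `COc1ccc(C2N=C(SCc3cccc(Cl)c3)NC(C)=C2C(=O)Nc2ccc(F)cc2)cc1OC`: 2.1%
compound 2 `COc1ccc(C2N=C(SCc3ccc(Cl)cc3)NC(C)=C2C(=O)Nc2ccc(F)cc2)cc1OC`: 3.1%
compound 3 `CC1=C(C(=O)Nc2ccc(F)cc2)C(c2ccc([N+](=O)[O-])cc2)N=C(SCc2cccc(Cl)c2)N1`: 2.1%

All three compounds were tested in a functional assay on the whole organism (artery, strain albino) with Rattus norvegicus as the target, with a stated time of 15 min, at a dose of 10 mg/kg by the oral route; on this read-out higher numbers stand for more inhibition at the one dose given (going by the name of the read-out) and lower numbers for less inhibition. Compound 2 differs from compound 1 by 4-chlorophenyl in place of 3-chlorophenyl on a saturated chain carbon bound to a sulfur, and this step gave a number 1 percentage points higher from compound 1 to compound 2 (within the scatter). Compound 3 differs from compound 1 in the core by 4-nitrophenyl in place of 3,4-dimethoxyphenyl on a saturated ring carbon, and that step gave no change at the digits printed from compound 1 to compound 3 (within the scatter). All three numbers in this assay are small and lie within the usual scatter of one another, so no order among them can be stated.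

Compound 4 `CC1=C(C(=O)Nc2ccc(F)cc2)C(c2ccc([N+](=O)[O-])cc2)N=C(SCc2ccc(Cl)cc2)N1` has not yet been measured in this assay. It differs from compound 3 by 4-chlorophenyl in place of 3-chlorophenyl on a saturated chain carbon bound to a sulfur, the same change as from compound 1 to compound 2, at the same place. Among the compounds with values here, compound 4 is therefore expected to give a step of a number 0.9 percentage points higher from compound 3 to compound 4 (within the scatter), a size resting on the one earlier example, a number 1 percentage points higher from compound 1 to compound 2 (within the scatter), which stayed within the scatter, and on the low value of compound 3, 2.1%. Compound 4 is thus estimated at 3%, with a range from -5% to 11% expected to hold most repeats.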

Compound 4, a percentage reported as inhibition, in the whole organism at one dose (the size of the read-out at that dose, not a potency): 3.6%
For compound 4 the middle estimate is 0.6 percentage points below the measured one; the range from low to high includes it.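

The change from 3-chlorophenyl to 4-chlorophenyl on a saturated chain carbon bound to a sulfur gave a number 1.5 percentage points higher from compound 3 to compound 4 (within the scatter) in this assay, and it read the same on both cores: the same change on two cores in this assay, a number 1 percentage points higher (within the scatter) from compound 1 to compound 2 and a number 1.5 percentage points higher (within the scatter) from compound 3 to compound 4, 0.5 percentage points apart, within the scatter of two such steps. The change to 4-nitrophenyl from 3,4-dimethoxyphenyl on a saturated ring carbon gave a number 0.5 percentage points higher from compound 2 to compound 4 (within the scatter), and it also read the same on both cores: the same change on two cores in this assay, no change at the digits printed (within the scatter) from compound 1 to compound 3 and a number 0.5 percentage points higher (within the scatter) from compound 2 to compound 4, 0.5 percentage points apart, within the scatter of two such steps. This shows that neither change left the scatter on either core, but it does not show that either change has a real effect that carries from one core to another, since every step is too small to tell from repeat variation.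

The compounds shown leave open whether any group at these two places can lift the read-out clear of the scatter. An amine or a carboxylic acid on the ring on the saturated ring carbon, or a longer chain in place of the chlorobenzyl, would test this.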